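One Double Bond Reversed in a Series at the Limit

The source may report more compounds than this note shows. Statements on the series, on what has been measured and on what is new or still open speak of the compounds shown alone.

In a functional assay on Bel-7402 cells (Homo sapiens) for cytotoxicity, read by MTT assay, with a stated time of 72 h (on this read-out lower numbers stand for stronger inhibition and higher numbers for weaker inhibition), compound 1 (`CCCCC(C)C[C@]1(CC)O[C@H]1[C@]1(CC)C=CC(=O)O1`) gives > 100000 nM and this is a limit of the assay, not a number. Compound 2 (`CCCCC(C)C/C(=C/[C@@]1(CC)OC(=O)C[C@@H]1O)CC`) gives > 100000 nM as a limit too. Compound 3 (`CCCCC(C)CC(O)(/C=C(/CC)[C@@H](O)CC(=O)OC)CC`) gives > 100000 nM as a limit as well. Compound 2 therefore stands with the other two at the limit of > 100000 nM in this assay, at which 3 of the 3 values shown sit, and no measured number separates the three.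

Compound 4 (`CCCCC(C)C/C(=C\[C@@]1(CC)OC(=O)C[C@@H]1O)CC`) has not yet been measured. The change from compound 2 is the two compounds have the same atoms and bonds; at least one stereo element is drawn with a configuration in one of them and without one in the other: 1 of 4 stereo elements differ; a double bond is drawn E in compound 2 and Z in compound 4 and nothing else: a double bond drawn E in compound 2 is drawn Z in compound 4. Within the data shown here, no measured step shows what such a change does here. The expected step of a number no higher from compound 2 to compound 4 (the limit leaves the size open) is estimated to lie within the scatter or to be a small gain in inhibition at most. Compound 4 is estimated at 100000 nM with an expected range from 40000 nM to 200000 nM. A limit of the assay may well be expected for it too.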

Compound 4, half-maximal inhibitory concentration: > 100000 nM
Compound 4 was reported as a limit; the forecaster's own chance of this, stated with the estimate: 80%; the middle value lies on the limit itself.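

Among these compounds, compound 2 and compound 4 both stand at a limit of the assay, and no step between them can be read. Going by these compounds, whether drawing the double bond E or Z changes inhibition in this assay at all stays open, as does any measured number for these four compounds.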